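This account rests on a few compounds, and the source may have more. Where it says the series, first, only, none or still open, it means among the compounds named here.

Compound 1 `COc1cccc(-c2csc(NC(=O)c3ccc([N+](=O)[O-])o3)n2)c1`: 58700 nM
Compound 2 `O=C(Nc1cccc(-c2csc(NC(=O)c3ccc([N+](=O)[O-])o3)n2)c1)c1ccccc1`: 50200 nM

Both were tested in an ADME assay on Vero cells (Chlorocebus sabaeus) for cytotoxicity, read by MTT assay, with a stated time of 72 h; a lower number here means a stronger inhibitor, a higher number a weaker inhibitor. Compound 2 gives the lowest of the two numbers, yet its neighbour compound 1 sits within the scatter of it, so neither can be called more or less toxic. Within the data shown here, the only measured step, a 1.2-fold lower number from compound 1 to compound 2 (0.07 log units; within the scatter), is within the scatter. Compound 3 `CS(=O)(=O)Nc1cccc(-c2csc(NC(=O)c3ccc([N+](=O)[O-])o3)n2)c1` differs from compound 2 by methylsulfonyl in place of benzoyl on a nitrogen on an aromatic ring. Among the measured compounds shown here, no measured step follows the same change, so the expectation rests only on the small step seen so far: compound 3 is expected to show a 1.2-fold higher number from compound 2 to compound 3 (0.08 log units; within the scatter), which would leave it at an estimated 60000 nM with a range from 25000 nM to 150000 nM.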

Compound 3, half-maximal inhibitory concentration: < 2820 nM
Compound 3 was reported as a limit (the forecaster's own chance of this, stated with the estimate: 25%); at least 21-fold (1.32 log units) between middle value and limit.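

The earlier pair suggested that this position barely responds to change, but methylsulfonyl in place of benzoyl on the nitrogen gives an at least 17-fold lower number from compound 2 to compound 3 (1.25 log units; beyond the scatter). Measured against the methoxy compound, the result is an at least 20-fold lower number from compound 1 to compound 3 (1.31 log units; beyond the scatter), so the group placed here can matter greatly. Compound 3 is reported only as a limit: the limit of < 2820 nM in this assay, at which 1 of the 3 values shown sits.

From the compounds shown here alone, its actual value remains open, and so does whether the step follows from gaining methylsulfonyl or losing the benzene ring. Acetyl or phenylsulfonyl on the same nitrogen would separate these two changes.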